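The compounds below may be only part of what the source reports. "The series", "measured", "known", "first", "only" and "open" are said of these compounds alone.

Measured in a functional assay on MCF7 cells (Homo sapiens) for antiproliferative activity, read by MTT assay, with a stated time of 72 h; a lower number here means a stronger inhibitor, a higher number a weaker inhibitor:
- compound 1 `COc1cc2c(Nc3cccc(C#N)c3)ncnc2cc1OCCCN1CCCC1`: 33900 nM
- compound 2 `COc1cc2c(Nc3ccccc3C#N)ncnc2cc1OCCCN1CCCC1`: 16200 nM

Of these two compounds, compound 2 has the lower number in this assay, which makes it the stronger inhibitor of the pair. Going by the values given here, the only measured step, a 2.1-fold lower number from compound 1 to compound 2 (0.32 log units; beyond the scatter), is modest and comes from moving to the 2-cyanophenyl group, not from any change on the side chain.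

Compound 3 `CCN1CCN(CCCOc2cc3ncnc(Nc4ccccc4C#N)c3cc2OC)CC1` keeps that 2-cyanophenyl group and differs from compound 2 at another place: 4-ethylpiperazin-1-yl in place of pyrrolidin-1-yl on a saturated chain carbon, three bonds along the chain from an oxygen on an aromatic ring. This puts 4-ethylpiperazin-1-yl in place of pyrrolidin-1-yl on a saturated chain carbon, three bonds along the chain from an oxygen on an aromatic ring. Among the compounds with values here, no measured step covers this change, so no direction can be drawn from the data. The starting point is compound 2 with 16200 nM. No shift past the scatter is expected for compound 3 from that value.

The estimate amounts to an expected 1.1-fold higher number from compound 2 to compound 3 (0.05 log units; within the scatter). Compound 3 is expected at 18000 nM, with an estimated range of 7000 nM to 45000 nM.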

Compound 3, half-maximal inhibitory concentration: 9070 nM
For compound 3 the middle estimate is 2.0-fold (0.30 log units) above the measured one, and the stated range covers the measured number.
By their numbers in this assay, from the lowest: compounds 3 and 2 (each within the scatter of the next); then compound 1.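

Going by these compounds alone, with the 2-cyanophenyl group held fixed, the side chain was varied for the first time, on a saturated chain carbon, three bonds along the chain from an oxygen on an aromatic ring. In this assay, replacing pyrrolidin-1-yl with 4-ethylpiperazin-1-yl gives a 1.8-fold lower number from compound 2 to compound 3 (0.25 log units; within the scatter), so going from a five-membered ring with 5 heavy atoms to a six-membered ring with 8 heavy atoms and 2 nitrogens does not move the number past the scatter at this place. No measured evidence accounts for this reading.

The compounds shown leave open how a morpholin-4-yl group, a dimethylamino group or an unsubstituted piperazin-1-yl group would read at this place. They also leave open how a shorter or longer chain would read, and whether the same exchange would give a similar step with the 3-cyanophenyl group.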